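Dimethylaminophenyl exchange on two cores, Vero cell tolerance

The source may hold more compounds than are shown below. What is called first, only, known or untested is meant among the compounds shown, and "the series" means these compounds.

In an ADME assay on Vero cells (Chlorocebus sabaeus) for cytotoxicity, read by sulforhodamine B assay, with a stated time of 3 days (a higher number here means that more compound is tolerated, a lower number that less compound is tolerated), compound 1 `CC1=C(C(=O)Nc2ccc(Cl)cc2)C(c2cccc(Cl)c2)C(C(=O)Nc2ccc(Cl)cc2)=C(C)N1` gives 12 ug/mL, while compound 2 `CC1=C(C(=O)Nc2ccc(Cl)cc2)C(c2ccc(N(C)C)cc2)C(C(=O)Nc2ccc(Cl)cc2)=C(C)N1` gives 155 ug/mL. The change 4-(dimethylamino)phenyl in place of 3-chlorophenyl on a saturated ring carbon made the step of a 13-fold higher number from compound 1 to compound 2 (1.11 log units; beyond the scatter). Compound 3 `COc1ccc(NC(=O)C2=C(C)NC(=S)NC2c2cccc(Cl)c2)cc1` gives 270 ug/mL in this assay; the difference between its core and the core of compound 1 is not broken down here. Compound 4 `COc1ccc(NC(=O)C2=C(C)NC(=S)NC2c2ccc(N(C)C)cc2)cc1` carries the change (4-(dimethylamino)phenyl in place of 3-chlorophenyl on a saturated ring carbon), the same kind of change as before, though the place differs: here the saturated ring carbon sits in a six-membered non-aromatic ring with 2 nitrogen, next to the ring nitrogen and next to the ring atom that bears a large group, rather than in a ring with 1 nitrogen next to two ring atoms that each bear a (4-chlorophenyl)carbamoyl group. Because compound 3 already stands at 270 ug/mL, a smaller step of a 1.6-fold higher number from compound 3 to compound 4 (0.19 log units; within the scatter) is expected than the earlier one. For compound 4 a value of 420 ug/mL is estimated, between 200 ug/mL and 850 ug/mL.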

Compound 4, half-maximal cytotoxic concentration: 500 ug/mL
Compound 4: middle estimate off by 1.2-fold (0.08 log units), on the low side; the measured number falls inside the stated range.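

On the second core, this assay shows that the exchange of 3-chlorophenyl for 4-(dimethylamino)phenyl gives a 1.9-fold higher number from compound 3 to compound 4 (0.27 log units; within the scatter), a step that cannot be told from the scatter. The size of the step therefore did not carry over from one core to the other, and the two steps differ: the same change on two cores in this assay, a 13-fold higher number (1.11 log units; beyond the scatter) from compound 1 to compound 2 and a 1.9-fold higher number (0.27 log units; within the scatter) from compound 3 to compound 4, 7.0-fold (0.84 log units) apart, beyond the scatter of two such steps. This rests on a single pair for each core, and it does not show which part of the cores accounts for the gap, or that a step beyond the scatter would appear on any further core.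

The compounds shown leave open how a primary amine or a carboxylic acid on that phenyl ring would behave on either core. Also open, on these data alone, is whether the gap remains when the 4-methoxyphenyl amide of compound 3 is replaced by the 4-chlorophenyl amide of compound 1.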